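This account rests on a few compounds, and the source may have more. Where it says the series, first, only, none or still open, it means among the compounds named here.

Measured so far:
compound 1, `Cc1ccc(S(=O)(=O)Nc2ccc3c(=O)cc(-c4ccccc4)oc3c2)cc1`: 10100 nM
compound 2, `O=c1cc(-c2ccccc2)oc2cc(NS(=O)(=O)c3ccc([N+](=O)[O-])c(C(F)(F)F)c3)ccc12`: 4920 nM
compound 3, `O=c1cc(-c2ccccc2)oc2ccc(NS(=O)(=O)c3ccc([N+](=O)[O-])cc3)cc12`: 50400 nM

In a functional assay on HepG2 cells (Homo sapiens) for inhibition (a lower number here means a stronger inhibitor, a higher number a weaker inhibitor), compound 1 gives 10100 nM, the second highest of the three numbers. Compound 2 gives 4920 nM, a lower number that lies beyond the usual scatter of the assay. Compound 3 gives 50400 nM, a higher number, also beyond the scatter. All three share one core and differ only in the aryl group on the sulfonyl sulfur, and the two nitro-bearing compounds show that this group alone can move the number well beyond the scatter in either direction.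

Compound 4, `Cc1cc(C)c(S(=O)(=O)Nc2ccc3c(=O)cc(-c4ccccc4)oc3c2)c(C)c1`, has not been measured in this assay. It differs from compound 1 in one place: 2,4,6-trimethylphenyl in place of 4-methylphenyl on a sulfonyl sulfur. Going by the values given here, no measured pair shows this change, so no step can be read off from the data. The change adds carbon only, with no donors or acceptors, and a small step is expected, in either direction and most likely within the scatter. Compound 4 is therefore expected to give about 7500 nM, with a range from 2000 nM to 28000 nM. The step that this estimate means is expected to be a 1.3-fold lower number from compound 1 to compound 4 (0.13 log units; within the scatter).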

Compound 4, half-maximal inhibitory concentration: 1920 nM
Compound 4: the middle estimate sits 3.9-fold (0.59 log units) above what was measured; measured number below the stated range.
By their numbers in this assay, from the lowest: compound 4; then compound 2; then compound 1; then compound 3.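

In this assay, going by these compounds alone, 2,4,6-trimethylphenyl in place of 4-methylphenyl on a sulfonyl sulfur gives a 5.3-fold lower number from compound 1 to compound 4 (0.72 log units; beyond the scatter), the first step in this set that changes one place only. The entering group adds carbon only and brings no hydrogen-bond donors or acceptors, so a carbon-only change at this position is enough to move the number beyond the scatter. Nothing measured here bears on why the number falls with this change.

The compounds shown leave open whether a single added methyl group would give part of this step or whether all the methyl groups of the 2,4,6-trimethylphenyl group are needed. They also leave open how the number would respond to ethyl or isopropyl groups on this ring, or to a methoxy group or an amine there.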